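From indole to quinoline on the amide carbonyl

This account rests on a few compounds, and the source may have more. Where it says the series, first, only, none or still open, it means among the compounds named here.

In a functional assay on SK-BR-3 cells (Homo sapiens) for antiproliferative activity, read by MTT assay, with a stated time of 72 h (on this read-out lower numbers stand for stronger inhibition and higher numbers for weaker inhibition), compound 3 `CCN1CCN(c2cc(C)c3cc(NC(=O)c4cc5ccccc5[nH]4)ccc3n2)CC1` gives 2550 nM, within the scatter of compound 2 `CCN1CCN(c2cc(C)c3cc(NC(=O)c4ccc(Cl)cc4)ccc3n2)CC1` at 3020 nM, while compound 1 `CCN1CCN(c2cc(C)c3cc(NC(=O)c4ccccc4C)ccc3n2)CC1` gives 29200 nM. Compound 4 `CCN1CCN(c2cc(C)c3cc(NC(=O)c4ccc5ccccc5n4)ccc3n2)CC1` carries quinolin-2-yl in place of 1H-indol-2-yl on a carbonyl carbon. The closest measured change is a 1.2-fold lower number from compound 2 to compound 3 (0.07 log units; within the scatter), which exchanged one aromatic group for another and stayed within the scatter. The larger steps, a 9.7-fold lower number from compound 1 to compound 2 (0.99 log units; beyond the scatter) and an 11-fold lower number from compound 1 to compound 3 (1.06 log units; beyond the scatter), both remove 2-methylphenyl, which plays no part here. Among the measured compounds shown here, no measured step tests quinolin-2-yl itself, so the expected change in this assay stays within the scatter, an estimated 1.4-fold higher number from compound 3 to compound 4 (0.14 log units; within the scatter). The expected value for compound 4 is 3500 nM, with an estimated range from 1300 nM to 9500 nM.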

Compound 4, half-maximal inhibitory concentration: 3760 nM
Compound 4: middle estimate off by 1.1-fold (0.03 log units), on the low side, within the range that was stated.
By their numbers in this assay, from the lowest: compounds 3, 2 and 4 (each within the scatter of the next); then compound 1.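

In this assay the group on the carbonyl carbon can give up its hydrogen-bond donor and take on a hydrogen-bond acceptor, with a six-membered ring holding the nitrogen instead of a five-membered one, and the result stays within the scatter (a 1.5-fold higher number from compound 3 to compound 4 (0.17 log units; within the scatter)). Quinolin-2-yl is likewise not told apart from 4-chlorophenyl (a 1.2-fold higher number from compound 2 to compound 4 (0.10 log units; within the scatter)), while 2-methylphenyl alone stands apart (a 7.8-fold lower number from compound 1 to compound 4 (0.89 log units; beyond the scatter)). No available evidence bears on why these results come out this way.

Going by these compounds, whether plain phenyl or a non-aromatic group such as cyclohexyl on the carbonyl carbon would give a similar number remains open.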